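The compounds below may be only part of what the source reports. "The series", "measured", "known", "first", "only" and "open" are said of these compounds alone.

Among the compounds with values here, in a functional assay on A549 cells (Homo sapiens) for inhibition, read by MTT assay, with a stated time of 72 h (a higher number here means a weaker inhibitor, a lower number a stronger inhibitor), compound 1 `COc1ccc(NC(=O)C2CCN(C/C=C/c3ccccc3)CC2)cc1` gives 83800 nM, the higher of the two numbers so far. Compound 2 `O=C(Nc1cccc(C(F)(F)F)c1)C1CCN(C/C=C/c2ccccc2)CC1` gives 15600 nM, lower by more than the scatter. Compound 3 `N#Cc1ccc(NC(=O)C2CCN(C/C=C/c3ccccc3)CC2)cc1` keeps the core of compound 1 and has cyano in place of methoxy on an aromatic carbon, para to a large group: cyano in place of methoxy on an aromatic carbon. Within the data shown here, no measured step isolates this change. Among the measured compounds shown here, the only guide is compound 2 at 15600 nM, which also carries no methoxy. In this assay a moderate estimated step toward a lower number is expected, a 2.8-fold lower number from compound 1 to compound 3 (0.45 log units; beyond the scatter). The expected value for compound 3 is 30000 nM, with an estimated range of 10000 nM to 75000 nM.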

Compound 3, half-maximal inhibitory concentration: 40200 nM
Compound 3: middle estimate off by 1.3-fold (0.13 log units), on the low side; the measured number falls inside the stated range.
By their numbers in this assay, from the lowest: compound 2; then compound 3; then compound 1.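

In this assay, within the data shown here, cyano in place of methoxy on an aromatic carbon, para to a large group, gives a 2.1-fold lower number from compound 1 to compound 3 (0.32 log units; beyond the scatter), the first step that isolates a change in one place. The number at this position therefore moves beyond the scatter with the rest of the structure held constant, though the step is modest. No measurement in hand explains this step.

From the compounds shown here alone, whether an amine or a carboxylic acid at this position would shift the number further remains open. Among these compounds, compound 2 differs from compound 3 in more than one place, so it gives no step for this position.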